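The source may hold more compounds than are shown below. What is called first, only, known or untested is meant among the compounds shown, and "the series" means these compounds.

Compound 1 `COc1ccc(C2=C(c3cc(OC)c(OC)c(OC)c3)C(=O)CC2C)cc1C(=O)O`, compound 2 `COc1ccc(C2=C(c3cc(OC)c(OC)c(OC)c3)C(=O)CC2O[SiH2]C(C)(C)C)cc1` and compound 3 `COc1ccc(C2=C(c3cc(OC)c(OC)c(OC)c3)C(=O)C(O)C2)cc1OC(C)C` share a core and have been measured in an ADME assay on HEp-2 cells (Homo sapiens) for cytotoxicity, read by MTT assay, with a stated time of 72 h; on this read-out higher numbers stand for weaker inhibition and lower numbers for stronger inhibition. Compound 1 gives > 100 ug/mL, which is a limit of the assay and not a number. Compound 3 gives > 100 ug/mL, which is also a limit. Compound 2 gives > 100 ug/mL, again a limit and not a number. It therefore has no exact position on the scale and stands level with the other two compounds, as the whole set so far shows: the limit of > 100 ug/mL in this assay, at which 3 of the 3 values shown sit.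

Compound 4 `COc1ccc(C2=C(c3cc(OC)c(OC)c(OC)c3)C(=O)CC2O[SiH2]C(C)(C)C)cc1O` differs from compound 2 in one place: hydroxy in place of hydrogen on an aromatic carbon. Put simply, this is hydroxy in place of hydrogen on an aromatic carbon, which changes 4-methoxyphenyl to 3-hydroxy-4-methoxyphenyl. Among the measured compounds shown here, no measured pair of compounds differs in only one place, so the data give no direct size for this step. None of the three measured compounds carries a hydroxy on an aromatic carbon either. With compound 2 at its limit of > 100 ug/mL, any expected movement points to lower numbers, meaning stronger inhibition, and it could be large. Compound 4 could also stay at the limit. The expected size of the change is an at least 33-fold lower number from compound 2 to compound 4 (1.52 log units; beyond the scatter). For compound 4 the estimated value is 3 ug/mL, with an expected range from 0.03 ug/mL to 100 ug/mL.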

Compound 4, half-maximal inhibitory concentration: 14.5 ug/mL
Estimate against measurement, compound 4: 4.8-fold (0.68 log units) below; low and high end bracket the measured number.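

Among the compounds shown here, a single hydroxy on an aromatic carbon, ortho to a methoxy group, is enough to bring a compound of this set off the limit in this assay: the change from 4-methoxyphenyl to 3-hydroxy-4-methoxyphenyl gives an at least 6.8-fold lower number from compound 2 to compound 4 (0.83 log units; beyond the scatter), the first step here that can be read at all. Compound 2 gives > 100 ug/mL, a limit and not a number, so the step has a floor but no true size. That floor is all the data can offer for this change, because the starting point sits where most of the values sit: the limit of > 100 ug/mL in this assay, at which 3 of the 4 values shown sit.

The compounds shown leave open whether this drop belongs to the hydroxy itself or would also come with another group on that aromatic carbon, such as an amine, a fluorine atom or a longer chain like ethoxy. Also open, from the compounds shown here alone, is whether the same hydroxy would lower the number as well with something other than the silyl ether on the shared core, for instance a plain alcohol.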